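Alkynyl heteroaryl swap on a cyclopropyl-fused adenosine scaffold

This account rests on a few compounds, and the source may have more. Where it says the series, first, only, none or still open, it means among the compounds named here.

Of the compounds shown here, three sharing one core have been measured in an assay on CHO cells for displacement of a labelled ligand from adenosine receptor A3 (Homo sapiens), read by scintillation counting, with a stated time of 60 min; a higher number here means a weaker inhibitor, a lower number a stronger inhibitor. Compound 1 `CNC(=O)[C@@]12C[C@@H]1[C@@H](n1cnc3c(NC)nc(C#Cc4cccc(C(F)(F)F)c4)nc31)[C@H](O)[C@@H]2O` gives 3.39 nM, compound 2 `CNC(=O)[C@@]12C[C@@H]1[C@@H](n1cnc3c(NC)nc(C#Cc4ccc(CO)cc4)nc31)[C@H](O)[C@@H]2O` gives 2.16 nM, and compound 3 `CNC(=O)[C@@]12C[C@@H]1[C@@H](n1cnc3c(NC)nc(C#Cc4cnn(C)c4)nc31)[C@H](O)[C@@H]2O` gives 2.34 nM. Among these three numbers compound 3 has compound 2 as its nearest neighbour and compound 1 as its furthest, and both gaps lie within the scatter. Compound 4 `CNC(=O)[C@@]12C[C@@H]1[C@@H](n1cnc3c(NC)nc(C#Cc4nccs4)nc31)[C@H](O)[C@@H]2O` differs from compound 3 only by 1,3-thiazol-2-yl in place of 1-methyl-1H-pyrazol-4-yl on a triple-bonded carbon. For the measured compounds named here, the steps that bear on this exchange of the group on the triple-bonded carbon, a 1.4-fold lower number from compound 1 to compound 3 (0.16 log units; within the scatter) and a 1.1-fold higher number from compound 2 to compound 3 (0.03 log units; within the scatter), were both within the scatter, as was a 1.6-fold lower number from compound 1 to compound 2 (0.20 log units; within the scatter). The step of a 1.2-fold higher number from compound 3 to compound 4 (0.08 log units; within the scatter) is therefore expected to be no change beyond the scatter. Compound 4 is estimated at 2.8 nM, with a range from 1.2 nM to 7 nM.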

Compound 4, inhibition constant: 2.1 nM
The estimate for compound 4 lay 1.3-fold (0.12 log units) above the measured number; the measured number falls inside the stated range.
By their numbers in this assay, from the lowest: compounds 4, 2, 3 and 1 (each within the scatter of the next).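

In this assay, a ring carrying sulfur, 1,3-thiazol-2-yl, is taken up on the triple-bonded carbon with no change beyond the scatter: a 1.1-fold lower number from compound 3 to compound 4 (0.05 log units; within the scatter), a 1.0-fold lower number from compound 2 to compound 4 (0.01 log units; within the scatter) and a 1.6-fold lower number from compound 1 to compound 4 (0.21 log units; within the scatter). All four groups at this place, the substituted phenyls and the five-membered aromatic rings alike, now lie within the scatter of one another. Nothing measured here accounts for this flatness. Still open, on these data alone, is whether an amine or a carboxylic acid on the ring, or a longer chain in its place, would move the number beyond the scatter.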